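The source may hold more compounds than are shown below. What is called first, only, known or untested is meant among the compounds shown, and "the series" means these compounds.

Compound 1 `Cc1ccccc1-c1nn(-c2ccc(F)cc2F)cc1CNCCCCO` — in an ADME assay on Huh-7 cells (Homo sapiens) for cytotoxicity (on this read-out higher numbers stand for lower toxicity in this test and lower numbers for higher toxicity in this test), compound 1 gives > 20000 nM, which is a limit of the assay and not a number.
Compound 2 `CN1CCN(CCNCc2cn(-c3ccc(F)cc3F)nc2-c2ccc(Cl)cc2)CC1` — in this assay compound 2 gives 19000 nM.
Compound 3 `Cc1ccccc1-c1nn(-c2ccc(OC(F)(F)F)cc2)cc1CNCCN1CCN(C)CC1` — in this assay compound 3 gives 17000 nM.

Compound 3 holds the lower of the two numbers, with compound 2 nearby at a gap within the scatter, while compound 1 sits at the limit of > 20000 nM in this assay, at which 1 of the 3 values shown sits. Compound 4 `Cc1ccccc1-c1nn(-c2cc(F)ccc2F)cc1CNCCN1CCN(C)CC1` differs from compound 3 in one place: 2,5-difluorophenyl in place of 4-(trifluoromethoxy)phenyl on an aromatic nitrogen. For the measured compounds named here, no measured pair shows this change. In this assay all three values sit close together or at the limit, so a step no larger than the scatter is expected, if anything toward a higher number. For compound 4 the estimate is 20000 nM, within 10000 nM to 40000 nM, which means an expected step of a 1.2-fold higher number from compound 3 to compound 4 (0.07 log units; within the scatter).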

Compound 4, half-maximal cytotoxic concentration: > 20000 nM
Compound 4: only a limit was reported; the forecaster's own chance of this, stated with the estimate: 50%; the middle value lies on the limit itself.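

Placing 2,5-difluorophenyl where 4-(trifluoromethoxy)phenyl stood on this aromatic nitrogen gives, in this assay, an at least 1.1-fold higher number from compound 3 to compound 4 (0.07 log units; that floor lies within the scatter), so this swap shows no sign of higher toxicity in this test. Compound 4 gives a limit of the assay and not a number, so the full size of the step cannot be read, and the values are crowding at that limit: the limit of > 20000 nM in this assay, at which 2 of the 4 values shown sit.

The compounds shown leave open whether any group on this nitrogen would lower the number. A pyridine ring or a phenyl ring carrying a nitrile or a carboxylic acid would test this.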